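Trimming One Methoxy from the Strongest Enone

The source may hold more compounds than are shown below. What is called first, only, known or untested is meant among the compounds shown, and "the series" means these compounds.

Three compounds share one core and an enone linking two methoxy-bearing phenyl rings. In a functional assay on A549 cells (Homo sapiens) for antiproliferative activity, read by MTT assay, with a stated time of 24 h (a higher number here means a weaker inhibitor, a lower number a stronger inhibitor), compound 1 `COc1ccc(-c2cc(/C=C/C(=O)c3cc(OC)c(OC)c(OC)c3)nc3cc(-c4ccccc4)nn23)cc1OC` gives 7200 nM, the lowest number of the three. Compound 3 `COc1ccc(C(=O)/C=C/c2cc(-c3cc(OC)c(OC)c(OC)c3)n3nc(-c4ccccc4)cc3n2)cc1OC` gives 17800 nM, and compound 2 `COc1cc(/C=C/C(=O)c2cc(-c3cc(OC)c(OC)c(OC)c3)n3nc(-c4ccccc4)cc3n2)cc(OC)c1OC` gives 25900 nM, both steps beyond the scatter, so compound 1 is the strongest inhibitor shown. Compound 4 `COc1ccc(C(=O)/C=C/c2cc(-c3ccc(OC)c(OC)c3)n3nc(-c4ccccc4)cc3n2)cc1OC` differs from compound 1 by hydrogen in place of methoxy on an aromatic carbon; the 3,4,5-trimethoxyphenyl becomes 3,4-dimethoxyphenyl. Among the compounds with values here, no measured pair shows this change, so its size is unknown. A modest step toward a weaker inhibitor is expected, near the edge of the scatter, as a 1.7-fold higher number from compound 1 to compound 4 (0.22 log units; within the scatter). Compound 4 is thus estimated at 12000 nM, likely between 4000 nM and 40000 nM.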

Compound 4, half-maximal inhibitory concentration: 3900 nM
Estimate against measurement, compound 4: 3.1-fold (0.49 log units) above; the measured number lies below the stated range.
By their numbers in this assay, from the lowest: compounds 4 and 1 (each within the scatter of the next); then compounds 3 and 2 (each within the scatter of the next).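

Taking one methoxy off the 3,4,5-trimethoxyphenyl to leave 3,4-dimethoxyphenyl does not weaken compound 4 in this assay. The change gives a 4.6-fold lower number from compound 3 to compound 4 (0.66 log units; beyond the scatter), while it gives a 1.8-fold lower number from compound 1 to compound 4 (0.27 log units; within the scatter), so the gain is clear only against compound 3, and this methoxy is not needed for activity in these compounds. Nothing available here bears on the reason for this result. Still open, from the compounds shown here alone, is whether an amine, a hydroxyl or a longer chain such as ethoxy at this position would match hydrogen, and whether the remaining methoxy groups can also go.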